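Thiophene for dimethylphenyl on the vinyl carbon of compound 3

A few compounds are considered here, and "the series" means these few. Any claim that something is new, unique, unknown or untested is made for them only; others in the source may bear on it.

Three members of this series have numbers in a functional assay on DU-145 cells (Homo sapiens) for inhibition, read by trypan blue exclusion, with a stated time of 96 h; on this read-out lower numbers stand for stronger inhibition of growth and higher numbers for weaker inhibition of growth. Compound 1 `COc1ccc(/C=C(\C(=O)c2ccc(Cl)cc2)S(=O)(=O)Cc2ccccc2Cl)cc1` gives 50000 nM, and compound 2 `Cc1ccc(S(=O)(=O)/C(=C/c2cccs2)C(=O)c2ccc(Cl)cc2)cc1` gives 25000 nM. Compound 3 `Cc1ccc(C)c(/C=C(\C(=O)c2ccc(Br)cc2)S(=O)(=O)Cc2ccc(F)cc2)c1` gives 1000 nM, the lowest of the three; its gap to compound 2, the nearest, and its gap to compound 1, the furthest, both lie beyond the usual scatter, so compound 3 stands as the strongest inhibitor of growth among the measured compounds.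

The next compound, compound 4 `Cc1ccc(/C=C(\C(=O)c2ccc(Br)cc2)S(=O)(=O)Cc2ccc(F)cc2)s1`, differs from compound 3 in one place: 5-methylthiophen-2-yl in place of 2,5-dimethylphenyl on a double-bonded chain carbon bound to a double-bonded chain carbon. The sulfonyl side and the bromophenyl ketone are kept. For the measured compounds named here, no measured pair shows this exchange on its own, so its size cannot be read from the data. Compound 2 also carries a thiophene on the double-bonded chain carbon, yet it differs from compound 3 in several other places, so it gives only a weak hint.

Compound 4 is expected to remain a clear inhibitor of growth, with a step from compound 3 of a 2.5-fold higher number from compound 3 to compound 4 (0.40 log units; beyond the scatter) in this assay, most likely toward a somewhat higher number. The estimate for compound 4 in this assay is 2500 nM, with a range from 600 nM to 10000 nM.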

Compound 4, concentration for 50% growth inhibition: 1000 nM
Estimate against measurement, compound 4: 2.5-fold (0.40 log units) above; low and high end bracket the measured number.
By their numbers in this assay, from the lowest: compounds 3 and 4 (each within the scatter of the next); then compounds 2 and 1 (each within the scatter of the next).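

In this assay, 5-methylthiophen-2-yl in place of 2,5-dimethylphenyl on a double-bonded chain carbon bound to a double-bonded chain carbon gives no change at the digits printed from compound 3 to compound 4 (within the scatter). For the compounds shown here, this is the first exchange that can be read on its own, with the sulfonyl side and the bromophenyl ketone kept. With these two parts held fixed, the position accepts one five-membered aromatic ring with 1 hetero atom as well as one six-membered aromatic ring of carbon only, so the growth inhibition of compound 3 does not depend on the 2,5-dimethylphenyl group alone; the data at hand offer no explanation for this match between the two groups.

As far as these compounds go, whether this tolerance extends beyond these two aromatic groups remains open, for instance to a morpholine, a carboxylic acid or a longer alkyl chain at the same place. Also open, from the compounds shown here alone, is whether the same exchange leaves the read-out unchanged when the bromophenyl ketone or the sulfonyl side is replaced.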